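Trimming the Ring-Nitrogen Substituent to Methyl

The source may hold more compounds than are shown below. What is called first, only, known or untested is meant among the compounds shown, and "the series" means these compounds.

Measured compounds:
Compound 1 `Cn1cc(-c2ccc(NC(=O)c3cn(CC4CCOCC4)cc(-c4ccc(F)cc4)c3=O)c(F)c2)c2c(N)ncnc21` 0.2 nM
Compound 2 `Cn1cc(-c2cc(F)c(NC(=O)c3cn(CC4CCOCC4)cc(-c4ccc(F)cc4)c3=O)cc2F)c2c(N)ncnc21` 0.5 nM
Compound 3 `Cn1cc(-c2ccc(NC(=O)c3cn(CC4CCCO4)cc(-c4ccc(F)cc4)c3=O)cc2)c2c(N)ncnc21` 1.2 nM

In an assay on isolated protein for inhibition of tyrosine-protein kinase receptor UFO (Homo sapiens), read by ELISA (a higher number here means a weaker inhibitor, a lower number a stronger inhibitor), compound 3 gives the highest number of the three. Compound 1 and compound 3 differ in two places, so only their values can be compared. Compound 4 `Cn1cc(C(=O)Nc2ccc(-c3cn(C)c4ncnc(N)c34)cc2)c(=O)c(-c2ccc(F)cc2)c1` differs from compound 3 by hydrogen in place of oxolan-2-yl on a saturated chain carbon bound to an aromatic nitrogen. Going by the values given here, the only single-site step measured, a 2.5-fold higher number from compound 1 to compound 2 (0.40 log units; beyond the scatter), concerns a fluoro on an aromatic carbon and does not bear on the substituent at the ring nitrogen, so no measured step speaks directly to this change. Compound 4 is therefore expected to show a modest weakening, a 2.5-fold higher number from compound 3 to compound 4 (0.40 log units; beyond the scatter), with wide uncertainty. The estimate for compound 4 in this assay is 3 nM, ranging from 0.8 nM to 12 nM.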

Compound 4, half-maximal inhibitory concentration: 5 nM
Compound 4: the middle estimate sits 1.7-fold (0.22 log units) below what was measured, within the range that was stated.
By their numbers in this assay, from the lowest: compound 1; then compound 2; then compound 3; then compound 4.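

Cutting (oxolan-2-yl)methyl back to methyl at the ring nitrogen gives the first measured step at this position, a 4.2-fold higher number from compound 3 to compound 4 (0.62 log units; beyond the scatter) in this assay. The substituent therefore affects the reading, yet the weakening is modest and the oxolan-2-yl ring is not needed for inhibition in this assay. No available evidence explains the size of this step.

On these data alone, it remains open whether a longer chain, a methoxyethyl group or an amine at this place would match the oxolan-2-yl group. As far as these compounds go, it is also open whether removing the ring substituent of compound 1 would cost a similar amount.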